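Ring-bearing amide after the methoxymethyl lead

The source may report more compounds than this note shows. Statements on the series, on what has been measured and on what is new or still open speak of the compounds shown alone.

Values in a functional assay on DU-145 cells (Homo sapiens) for antiproliferative activity, read by sulforhodamine B assay, with a stated time of 3 days; a lower number here means a stronger inhibitor of growth, a higher number a weaker inhibitor of growth:
- compound 1 `O=C(Nc1nccs1)c1cccc(Nc2ncc(F)c(Nc3ccc(F)cc3)n2)c1`: > 10000 nM (a limit, not a number)
- compound 2 `O=C(Nc1cccc(Nc2ncc(F)c(Nc3ccc(F)cc3)n2)c1)c1cnccn1`: 26400 nM
- compound 3 `COCC(=O)Nc1cccc(Nc2ncc(F)c(Nc3ccc(F)cc3)n2)c1`: 4460 nM

Of the two actual numbers, the lower belongs to compound 3 at 4460 nM. The value of compound 1 is a limit only.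

Compound 4 `Cn1ccnc1NC(=O)c1cccc(Nc2ncc(F)c(Nc3ccc(F)cc3)n2)c1` carries (1-methyl-1H-imidazol-2-yl)carbamoyl in place of ((methoxymethyl)carbonyl)amino on an aromatic carbon. This reverses the kind of change seen in two measured steps: an at least 2.2-fold lower number from compound 1 to compound 3 (0.35 log units; beyond the scatter) and a 5.9-fold lower number from compound 2 to compound 3 (0.77 log units; beyond the scatter). The first gives only a minimum size, since it starts from the limit of compound 1. Compound 1, with (1,3-thiazol-2-yl)carbamoyl, is the nearest match to compound 4, and compound 2 also bears an aromatic ring here. Both lie higher than compound 3, so a move of modest size towards weaker growth inhibition is expected in this assay. The expected step is a 2.7-fold higher number from compound 3 to compound 4 (0.43 log units; beyond the scatter). The estimate for compound 4 is 12000 nM, with an expected range of 4000 nM to 35000 nM.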

Compound 4, concentration for 50% growth inhibition: 15100 nM
Estimate against measurement, compound 4: 1.3-fold (0.10 log units) below; the measured number falls inside the stated range.
By their numbers in this assay, from the lowest: compound 3; then compounds 4 and 2 (each within the scatter of the next).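

In this assay, (1-methyl-1H-imidazol-2-yl)carbamoyl gives a 3.4-fold higher number from compound 3 to compound 4 (0.53 log units; beyond the scatter), the first actual number showing a carbamoyl-linked ring on the weaker side of the methoxymethyl amide. The other readable step is a 1.7-fold lower number from compound 2 to compound 4 (0.24 log units; within the scatter), so the imidazole carbamoyl and the pyrazine amide, whose amide linkages run in opposite directions, cannot be told apart here. Compound 1 has only a limit, and its steps cannot be read: the limit of > 10000 nM in this assay, at which 1 of the 4 values shown sits.

Open is whether the gap to compound 3 follows the ring or the direction of the amide, as no methoxymethyl group on a carbamoyl linkage appears among these compounds. Also open, from the compounds shown here alone, is how a primary amine, a carboxylic acid or a longer ether chain at this position would compare with compound 3.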